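Bromo substituent on the aryl ring of compound 1

The source may report more compounds than this note shows. Statements on the series, on what has been measured and on what is new or still open speak of the compounds shown alone.

Measured compounds in a functional assay on HT-29 cells (Homo sapiens) for cytotoxicity, read by MTT assay, with a stated time of 24 h; a higher number here means a weaker inhibitor, a lower number a stronger inhibitor:
compound 1 `NS(=O)(=O)c1ccc(C/N=C/c2ccccc2OCc2cn(CCCOc3ccc4ccc(=O)oc4c3)nn2)cc1`: 14300 nM
compound 2 `COc1cccc(/C=N/Cc2ccc(S(N)(=O)=O)cc2)c1OCc1cn(CCCOc2ccc3ccc(=O)oc3c2)nn1`: 52500 nM
compound 3 `CCN(CC)c1ccc(/C=N/Cc2ccc(S(N)(=O)=O)cc2)c(OCc2cn(CCCOc3ccc4ccc(=O)oc4c3)nn2)c1`: 23300 nM

Compound 1 gives the lowest of the three numbers in this assay. Compound 3 sits nearest to it, the step of a 1.6-fold higher number from compound 1 to compound 3 (0.21 log units; within the scatter) lying within the scatter, so no order between compound 1 and compound 3 can be claimed. Compound 2 lies furthest away, the step of a 3.7-fold higher number from compound 1 to compound 2 (0.56 log units; beyond the scatter) being beyond the scatter.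

The unmeasured compound 4 `NS(=O)(=O)c1ccc(C/N=C/c2cc(Br)ccc2OCc2cn(CCCOc3ccc4ccc(=O)oc4c3)nn2)cc1` differs from compound 1 in one place: bromo in place of hydrogen on an aromatic carbon. The two measured steps from compound 1 both add a substituent to the same six-membered ring, though not at the place taken by the bromo group in compound 4. One of them, the methoxy step, gave a modest rise in the number; the other, the diethylamino step, stayed within the scatter. Neither points to a large move in either direction, and a bromo group has not been measured anywhere in this set.

For compound 4 the expectation in this assay is therefore a number close to that of compound 1, at most a small rise, the step being estimated as a 1.1-fold higher number from compound 1 to compound 4 (0.05 log units; within the scatter). The estimate for compound 4 is 16000 nM, with a range from 7000 nM to 40000 nM.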

Compound 4, half-maximal inhibitory concentration: 17700 nM
For compound 4 the middle estimate is 1.1-fold (0.04 log units) below the measured one; the measured number falls inside the stated range.
By their numbers in this assay, from the lowest: compounds 1, 4 and 3 (each within the scatter of the next); then compound 2.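

In this assay, bromo in place of hydrogen, on the aromatic carbon meta to a large group and para to a large group, gives a 1.2-fold higher number from compound 1 to compound 4 (0.09 log units; within the scatter) and so leaves no readable difference at this place. It is the only halogen among the compounds shown and the only substituent at this carbon, and it resembles the diethylamino step, a 1.6-fold higher number from compound 1 to compound 3 (0.21 log units; within the scatter), rather than the methoxy step, a 3.7-fold higher number from compound 1 to compound 2 (0.56 log units; beyond the scatter), which alone lies beyond the scatter. No measurement available here speaks to the reason for this result.

From the compounds shown here alone, whether a chloro or fluoro atom, a nitrile, an amine or a carboxylic acid on this same carbon would also stay within the scatter of compound 1 remains open. Also open, going by these compounds, is how bromo would read when combined with the methoxy group of compound 2 or the diethylamino group of compound 3.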